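The source may report more compounds than this note shows. Statements on the series, on what has been measured and on what is new or still open speak of the compounds shown alone.

Working notes on the series.

Compound 1, `CCCn1c(NC(=O)c2ccc3ccccc3n2)nc2cc(C(N)=O)cc(OC)c21`, is the parent of the set. In an assay for activation of interferon regulatory factor 3 (Homo sapiens), read by a luciferase reporter, with a stated time of 20 h (a higher number here means that more compound is needed for the effect, a lower number that less compound is needed), compound 1 gives only a limit, > 100000 nM. Compound 2, `CCCn1c(NC(=O)c2cc3ccccc3n2C)nc2cc(C(N)=O)cc(OC)c21`, is the same core with 1-methyl-1H-indol-2-yl in place of quinolin-2-yl on the carbonyl carbon. In this assay compound 2 likewise gives a limit, > 100000 nM. Compound 3, `COc1cc(C(N)=O)cc2nc(NC(=O)c3ccc4ccccc4n3)n(CCCNC(=O)OCc3ccccc3)c12`, carries (benzyloxycarbonyl)amino in place of hydrogen on a saturated chain carbon, three bonds along the chain from an aromatic nitrogen. In this assay compound 3 also stands at a limit, > 100000 nM.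

The two measured steps, a step that the two limits leave unreadable from compound 1 to compound 2 and a step that the two limits leave unreadable from compound 1 to compound 3, are therefore unreadable in size and direction, because of the limit of > 100000 nM in this assay, at which 3 of the 3 values shown sit.

Compound 4, `COc1cc(C(N)=O)cc2nc(NC(=O)C3CCN(C)CC3)n(CCCNC(=O)OCc3ccccc3)c12`, differs from compound 3 by 1-methylpiperidin-4-yl in place of quinolin-2-yl on a carbonyl carbon. Going by the values given here, no measured step touches this change: the only step at the carbonyl carbon, from quinolin-2-yl to 1-methyl-1H-indol-2-yl, is unreadable, and the (benzyloxycarbonyl)amino chain is kept unchanged. With every value in the set sitting at the limit, no direction can be read, and the step from compound 3 to compound 4 is estimated as a number no higher from compound 3 to compound 4 (the limit leaves the size open). Compound 4 is thus expected to give about 100000 nM in this assay, with a broad range from 10000 nM to 300000 nM, and most likely another limit.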

Compound 4, half-maximal effective concentration: > 100000 nM
Compound 4 gave a limit, no number (the forecaster's own chance of this, stated with the estimate: 80%); the middle value sits exactly at the limit.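

The step from compound 3 to compound 4 cannot be read in size or direction, because compound 4 also gives only a limit: the limit of > 100000 nM in this assay, at which 4 of the 4 values shown sit.

The compounds shown leave open whether quinolin-2-yl, 1-methyl-1H-indol-2-yl or 1-methylpiperidin-4-yl on the carbonyl carbon makes any difference in this assay, as none of them yields a half-maximal effective concentration as a number.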